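A 2-fluorophenyl analogue in an adenosine receptor series

A few compounds are considered here, and "the series" means these few. Any claim that something is new, unique, unknown or untested is made for them only; others in the source may bear on it.

Compound 1, `CCCn1c(=O)[nH]c2nc(-c3ccc(S(=O)(=O)N4CCN(c5ccc(Br)cc5)CC4)cc3)[nH]c2c1=O`, gives in an assay on CHO cells for displacement of a labelled ligand from adenosine receptor A1 (Homo sapiens), read by scintillation counting, with a stated time of 90 min, in the presence of a further agent that is not named here (a lower number here means a stronger inhibitor, a higher number a weaker inhibitor), a limit of > 1000 nM.
Compound 2, `CCCn1c(=O)[nH]c2nc(-c3ccc(S(=O)(=O)N4CCN(C)CC4)cc3)[nH]c2c1=O`, gives in this assay 334 nM.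
Compound 3, `CCCn1c(=O)[nH]c2nc(-c3ccc(S(=O)(=O)N4CCN(c5ccccc5Br)CC4)cc3)[nH]c2c1=O`, gives in this assay a limit of > 1000 nM.

Compound 3 therefore stands only at a limit, and compound 1 sits at the same limit (the limit of > 1000 nM in this assay, at which 2 of the 3 values shown sit); compound 2 alone has a number. Compound 4, `CCCn1c(=O)[nH]c2nc(-c3ccc(S(=O)(=O)N4CCN(c5ccccc5F)CC4)cc3)[nH]c2c1=O`, differs from compound 3 by fluoro in place of bromo on an aromatic carbon. For the measured compounds named here, of the measured steps, the nearest is the one from compound 2 to compound 3, an at least 2.9-fold higher number from compound 2 to compound 3 (0.47 log units; beyond the scatter), and the step of an at least 2.9-fold lower number from compound 1 to compound 2 (0.47 log units; beyond the scatter) reads the same way in reverse; the step that the two limits leave unreadable from compound 1 to compound 3 cannot be read. Both aryl groups on the ring nitrogen thus sit at the limit, and nothing measured separates the two halogens. The step that the limit leaves unreadable from compound 3 to compound 4 is expected to be small, and compound 4 is estimated at 1500 nM, with a range from 400 nM to 6000 nM, most likely again reported as a limit.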

Compound 4, inhibition constant: > 1000 nM
Compound 4: only a limit was reported; the forecaster's own chance of this, stated with the estimate: 60%; the middle value is on the limit's open side.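

In this assay compound 4 is reported only as a limit, > 1000 nM, which places the 2-fluorophenyl group with both bromophenyl groups: the limit of > 1000 nM in this assay, at which 3 of the 4 values shown sit. Measured against the methyl group on the same ring nitrogen, the 2-fluorophenyl group gives an at least 2.9-fold higher number from compound 2 to compound 4 (0.47 log units; beyond the scatter), and this shows that the exchange of bromo for fluoro on this aromatic carbon does not bring the value back to a measured number. The steps among the compounds at the limit cannot be read, and fluoro and bromo therefore remain unseparated at this place.

On these data alone, how far beyond the limit each of the aryl compounds lies remains open. Also open, as far as these compounds go, is whether an unsubstituted phenyl, a benzyl or an ethyl group on this ring nitrogen would give a measured number, and where such a value would fall relative to the methyl group.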